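Series notes: aryl swap on the hydroxymethyl side chain

A few compounds are considered here, and "the series" means these few. Any claim that something is new, unique, unknown or untested is made for them only; others in the source may bear on it.

Compound 2 `COc1cc(F)cc([C@@H](CO)N2Cc3cc(-c4nc(Nc5ccnn5C)ncc4C)cn3C2=O)c1` gives 89.6 nM in a functional assay on COLO 205 cells (Homo sapiens) for antiproliferative activity, read by luminescence, with a stated time of 72 h; on this read-out lower numbers stand for stronger inhibition and higher numbers for weaker inhibition; among the two compounds with a reported number it carries the higher one, but its nearest neighbour, compound 1 `Cc1cnc(Nc2ccnn2C)nc1-c1cc2n(c1)C(=O)N([C@H](CO)c1cccc(Cl)c1)CC2` with 77.1 nM, sits within the scatter of it, so no order between them is claimed. Compound 3 `C[C@H](CO)Nc1ncc(Cl)c(-c2cc3n(c2)C(=O)N([C@H](CO)c2cccc(Cl)c2)C3)n1` is reported as "not active" (no number reported) in this assay, with no number. Compound 4 `Cc1cnc(Nc2ccnn2C)nc1-c1cc2n(c1)C(=O)N([C@H](CO)c1ccc(Cl)c(F)c1)C2` is not yet measured. It differs from compound 2 in one place: 4-chloro-3-fluorophenyl in place of 3-fluoro-5-methoxyphenyl on a saturated chain carbon bound to an amide-type nitrogen in a ring and a saturated chain carbon. For the measured compounds named here, no measured pair shows this change, so its size is not known from the data. Both aryl groups in the measured pair carry a halogen and sit at similar potency, so the change is expected to stay within the scatter, with the step of a 1.3-fold lower number from compound 2 to compound 4 (0.11 log units; within the scatter) expected to be small. For compound 4 the expected value is 70 nM, with a range from 25 nM to 200 nM.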

Compound 4, half-maximal inhibitory concentration: 92.2 nM
Compound 4: middle estimate off by 1.3-fold (0.12 log units), on the low side, within the range that was stated.
By their numbers in this assay, from the lowest: compounds 1, 2 and 4 (each within the scatter of the next).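

On a saturated chain carbon bound to an amide-type nitrogen in a ring and a saturated chain carbon, 4-chloro-3-fluorophenyl in place of 3-fluoro-5-methoxyphenyl gives a 1.0-fold higher number from compound 2 to compound 4 (0.01 log units; within the scatter) in this assay on the shared core. For the compounds shown here, this is the first step measured at this position, and this aryl exchange leaves the number within the scatter. No measurement on hand accounts for this result.

From the compounds shown here alone, whether an amine or a carboxylic acid at this place would hold the number in this assay remains open. The compounds shown also do not separate the contribution of the chlorine from that of the fluorine.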